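A few compounds are considered here, and "the series" means these few. Any claim that something is new, unique, unknown or untested is made for them only; others in the source may bear on it.

Compound 1 `Cc1ccc(Nc2nc(C)c(C(=O)/C=C/c3ccc(Cl)cc3)s2)cc1` was tested in a functional assay on NCI-H460 cells (Homo sapiens) for cytotoxicity, read by MTT assay (on this read-out higher numbers stand for weaker inhibition and lower numbers for stronger inhibition), and gave only a limit of the assay, > 25000 nM. Compound 2 `COc1cc(/C=C/C(=O)c2sc(Nc3cccc(Cl)c3)nc2C)cc(OC)c1OC` likewise gave only a limit in this assay, > 25000 nM. Going by the values given here, both values sit at the limit of > 25000 nM in this assay, at which 2 of the 2 values shown sit, so neither compound stands anywhere on a numbered scale, and no measured step between them exists. Compound 3 `Cc1nc(Nc2ccc(Cl)c(Cl)c2)sc1C(=O)/C=C/c1ccc(Cl)cc1` differs from compound 1 by 3,4-dichlorophenyl in place of 4-methylphenyl on a nitrogen on an aromatic ring. Among the compounds with values here, no step of this kind has been measured, so the expected change is a step that the limit leaves unreadable from compound 1 to compound 3, nothing beyond the usual scatter. Compound 3 is therefore estimated at 30000 nM in this assay, within a range from 8000 nM to 120000 nM.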

Compound 3, half-maximal inhibitory concentration: > 25000 nM
Compound 3: only a limit was reported (the forecaster's own chance of this, stated with the estimate: 70%); the middle value does not contradict the limit.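

Going by these compounds alone, compound 1 and compound 3 both give only a limit in this assay, so no step between them can be read: the limit of > 25000 nM in this assay, at which 3 of the 3 values shown sit. The compounds shown leave open which change to the shared core, if any, would give a readable number in this assay.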